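Taking the hydroxy group off compound 3

The source may hold more compounds than are shown below. What is called first, only, known or untested is meant among the compounds shown, and "the series" means these compounds.

compound 1 `Clc1ccc(-c2nnc(SCCCN3CCN(c4nc5ccccc5s4)CC3)o2)cc1`: 116000 nM
compound 2 `CC(C)(C)Oc1ccc(-c2nnc(SCCCN3CCN(c4nc5ccccc5s4)CC3)o2)cc1`: 89300 nM
compound 3 `Oc1ccc(-c2nnc(SCCCN3CCN(c4nc5ccccc5s4)CC3)o2)cc1`: 81900 nM

In a functional assay on MCF7 cells (Homo sapiens) for inhibition, read by MTT assay, with a stated time of 72 h (a higher number here means a weaker inhibitor, a lower number a stronger inhibitor), compound 3 sits level with the other two compounds, since all three values lie within the usual scatter of one another. Compound 4 `c1ccc(-c2nnc(SCCCN3CCN(c4nc5ccccc5s4)CC3)o2)cc1` has not yet been measured. It carries hydrogen in place of hydroxy on an aromatic carbon, para to a large group (hydrogen in place of hydroxy on an aromatic carbon), so 4-hydroxyphenyl becomes phenyl.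

Among the compounds with values here, three measured steps bear on this change, because each alters the group at that same aromatic carbon: (a 1.3-fold lower number from compound 1 to compound 2 (0.11 log units; within the scatter)), (a 1.4-fold lower number from compound 1 to compound 3 (0.15 log units; within the scatter)) and (a 1.1-fold lower number from compound 2 to compound 3 (0.04 log units; within the scatter)). All three stayed within the scatter. Bare phenyl itself is still untested, so this is an extrapolation. Nothing in these steps points to a direction, and no shift beyond the scatter is expected in this assay for this swap. The estimated step (a 1.2-fold higher number from compound 3 to compound 4 (0.06 log units; within the scatter)) is expected to remain within the scatter. For compound 4 the estimated value is 95000 nM (expected range 55000 nM to 160000 nM).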

Compound 4, half-maximal inhibitory concentration: 76900 nM
Compound 4: middle estimate off by 1.2-fold (0.09 log units), on the high side; measured number inside the range.
By their numbers in this assay, from the lowest: compounds 4, 3, 2 and 1 (each within the scatter of the next).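

Bare phenyl gives this aromatic carbon a case with no substituent at all, and in this assay it stands level with the chloro, tert-butoxy and hydroxy compounds (a 1.1-fold lower number from compound 3 to compound 4 (0.03 log units; within the scatter); a 1.2-fold lower number from compound 2 to compound 4 (0.06 log units; within the scatter); a 1.5-fold lower number from compound 1 to compound 4 (0.18 log units; within the scatter)). The earlier steps shown here only exchanged one group for another, whereas these show that removing the group altogether, including the hydrogen-bond donor and acceptor of the hydroxy, also leaves the reading within the scatter. No measurement here offers a reason for this flat result.

An amine, a carboxylic acid or a longer chain at this same carbon might still move the number beyond the scatter, and the compounds shown cannot say. As far as these compounds go, what a change elsewhere on the shared core would do also remains open.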